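Swapping the Amide Aryl Group for a Pyridin-2-yl

The source may report more compounds than this note shows. Statements on the series, on what has been measured and on what is new or still open speak of the compounds shown alone.

Compound 1 `COc1cc2c(cc1OC)C(CC(=O)Nc1ccc(Br)cc1)CC2`: 50%
Compound 2 `COc1cc2c(cc1OC)C(CC(=O)Nc1ccccc1C)CC2`: 21.9%
Compound 3 `COc1ccccc1NC(=O)CC1CCc2cc(OC)c(OC)cc21`: 28.1%

These three compounds share one core and differ only in the aryl group carried on the amide-type nitrogen. Measured in a functional assay on the whole organism (strain Wistar) for inhibition, with Rattus norvegicus as the target, read by paw edema, with a stated time of 1 h, at a dose of 100 mg/kg (on this read-out higher numbers stand for more inhibition at the one dose given (going by the name of the read-out) and lower numbers for less inhibition), compound 3 gives 28.1%, the second highest of the three numbers. Its nearest neighbour is compound 2, whose value lies within the scatter of repeated measurements (a number 6.2 percentage points higher from compound 2 to compound 3 (within the scatter)), so no order can be read between them. Compound 1 stands clearly apart: the step of a number 21.9 percentage points lower from compound 1 to compound 3 (beyond the scatter) is beyond the scatter, as is a number 28.1 percentage points lower from compound 1 to compound 2 (beyond the scatter).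

Compound 4 `COc1cc2c(cc1OC)C(CC(=O)Nc1ccccn1)CC2` is not yet measured. Its change from compound 3 is pyridin-2-yl in place of 2-methoxyphenyl on an amide-type nitrogen.

Within the data shown here, no measured step swaps an aryl ring for a heteroaryl ring, so none bears directly on this change. Among the measured compounds shown here, the only step at the same place that keeps a six-membered aromatic ring, a number 6.2 percentage points higher from compound 2 to compound 3 (within the scatter), lies within the scatter; the two steps that do exceed it both start from compound 1 and lead downward into the range where compounds 2 and 3 sit. With no direct guide, the expected step in this assay is none beyond the scatter, a number 0.1 percentage points lower from compound 3 to compound 4 (within the scatter).

Compound 4 is therefore estimated at 28%, within 12% to 45%.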

Compound 4, a percentage reported as inhibition, in the whole organism at one dose (the size of the read-out at that dose, not a potency): 25%
The estimate for compound 4 lay 3 percentage points above the measured number; low and high end bracket the measured number.
By their numbers in this assay, from the lowest: compounds 2, 4 and 3 (each within the scatter of the next); then compound 1.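

In this assay, among these compounds, this is the first change at the amide-type nitrogen from a carbon-only aromatic ring to a ring with one hetero atom, and the swap from 2-methoxyphenyl to pyridin-2-yl gives a number 3.1 percentage points lower from compound 3 to compound 4 (within the scatter) with no order to be read. The swap from 2-methylphenyl to pyridin-2-yl likewise gives a number 3.1 percentage points higher from compound 2 to compound 4 (within the scatter) so compounds 2, 3 and 4 form one group, even though the entering ring has fewer heavy atoms than the rings it replaces and a different ring make-up. Among the compounds shown here, only the swap from 4-bromophenyl stands out, with a number 25 percentage points lower from compound 1 to compound 4 (beyond the scatter) and compound 1 remains the only compound clearly apart from the others. Nothing given here explains why these aryl groups group this way.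

The compounds shown leave open whether the higher number of compound 1 depends on the bromine itself or on the whole 4-bromophenyl group, which a 4-chlorophenyl or plain phenyl group on the same nitrogen could help to separate. They also leave open how a pyridin-3-yl or pyridin-4-yl ring, or a bromine-bearing pyridine ring, would read at this position.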